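A Trifluoromethyl Step from Compound 1

This account rests on a few compounds, and the source may have more. Where it says the series, first, only, none or still open, it means among the compounds named here.

Compound 1 `O=C(Nc1cccc(/C=C/C(=O)c2nc3ccccc3[nH]2)c1)c1ccccc1`: 8340 nM
Compound 2 `O=C(/C=C/c1cccc(NC(=O)c2ccccc2Br)c1)c1nc2ccccc2[nH]1`: 6050 nM

In a functional assay on 143B cells (Homo sapiens) for antiproliferative activity, read by MTT assay, with a stated time of 48 h (a higher number here means a weaker inhibitor, a lower number a stronger inhibitor), compound 1 gives 8340 nM and stands within the scatter of compound 2, which gives 6050 nM in this assay. For the measured compounds named here, the one measured step, a 1.4-fold lower number from compound 1 to compound 2 (0.14 log units; within the scatter), is bromo in place of hydrogen on an aromatic carbon. Compound 3 `O=C(Nc1cccc(/C=C/C(=O)c2nc3ccccc3[nH]2)c1)c1cccc(C(F)(F)F)c1` differs from compound 1 by trifluoromethyl in place of hydrogen on an aromatic carbon. Going by the values given here, the bromo step is the only guide, and it did not move the number beyond the scatter, so no step beyond the scatter is expected from compound 1 to compound 3. Compound 3 is therefore estimated at 6500 nM, within 2500 nM to 16000 nM, that is a 1.3-fold lower number from compound 1 to compound 3 (0.11 log units; within the scatter).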

Compound 3, half-maximal inhibitory concentration: 9570 nM
Compound 3: middle estimate off by 1.5-fold (0.17 log units), on the low side, and the stated range covers the measured number.
By their numbers in this assay, from the lowest: compounds 2, 1 and 3 (each within the scatter of the next).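

In this assay, trifluoromethyl on an aromatic carbon, meta to a large group, is a second substituent on this phenyl ring that leaves the number within the scatter (a 1.1-fold higher number from compound 1 to compound 3 (0.06 log units; within the scatter)). Exchanging 2-bromophenyl for 3-(trifluoromethyl)phenyl also stays within the scatter (a 1.6-fold higher number from compound 2 to compound 3 (0.20 log units; within the scatter)), so neither of these two groups separates from the other or from hydrogen here. No evidence on the reason for these numbers is at hand.

Open, as far as these compounds go, is whether an amine or a carboxylic acid on this ring would give a step beyond the scatter. Also open, from the compounds shown here alone, is whether trifluoromethyl and bromo would read the same if each took the other's place on the ring.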